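The compounds below may be only part of what the source reports. "The series", "measured", "known", "first", "only" and "open" are said of these compounds alone.

The series rests on one shared core, decorated at two aromatic rings. Compound 1 `O=C(Nc1nc2ccc(F)cc2s1)c1cn(-c2ccccc2)nc1-c1ccc(F)cc1` gives 16700 nM in an ADME assay on HEK-293T cells (Homo sapiens) for cytotoxicity, read by MTT assay, with a stated time of 72 h; on this read-out lower numbers stand for stronger inhibition and higher numbers for weaker inhibition. Compound 2 `O=C(Nc1nc2ccc(F)cc2s1)c1cn(-c2ccccc2)nc1-c1ccc(Cl)cc1` differs from it by a chloro in place of fluoro on an aromatic carbon, and the step of an at least 2.9-fold higher number from compound 1 to compound 2 (0.47 log units; beyond the scatter) runs toward weaker inhibition. For compound 2 the read-out in this assay is a limit, > 50000 nM (the limit of > 50000 nM in this assay, at which 1 of the 3 values shown sits). Going by the values given here, compound 3 `COc1ccc(-c2nn(-c3ccccc3)cc2C(=O)Nc2nc3ccccc3s2)cc1` gives 18900 nM in this assay; it is one of only two numbers read, and it sits so close to that of compound 1 that the scatter covers the gap, so no order between compound 3 and compound 1 can be claimed.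

Compound 4 `COc1ccc(-c2nn(-c3ccccc3)cc2C(=O)Nc2nc3ccc(F)cc3s2)cc1` differs from compound 3 by fluoro in place of hydrogen on an aromatic carbon. Among the compounds with values here, no measured step touches that ring: the only step in hand, an at least 2.9-fold higher number from compound 1 to compound 2 (0.47 log units; beyond the scatter), exchanges halogens on the other aryl ring and says nothing about adding fluoro to the fused system. She therefore expects for compound 4 a step of a 1.1-fold lower number from compound 3 to compound 4 (0.02 log units; within the scatter) that stays within the scatter. Her estimate for compound 4 in this assay is 18000 nM, between 8000 nM and 45000 nM.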

Compound 4, half-maximal inhibitory concentration: 15400 nM
For compound 4 the middle estimate is 1.2-fold (0.07 log units) above the measured one; the range from low to high includes it.
By their numbers in this assay, from the lowest: compounds 4, 1 and 3 (each within the scatter of the next). At a limit, above all of these: compound 2.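

Going by these compounds alone, the change from 1,3-benzothiazol-2-yl to 6-fluoro-1,3-benzothiazol-2-yl gives the first reading at this position, and in this assay it shifts nothing beyond the scatter, with a 1.2-fold lower number from compound 3 to compound 4 (0.09 log units; within the scatter). With that fluoro held in place, the other aryl ring can now be compared across three groups: methoxy and fluoro cannot be told apart, with a 1.1-fold lower number from compound 1 to compound 4 (0.04 log units; within the scatter), while methoxy and chloro can, with an at least 3.2-fold lower number from compound 2 to compound 4 (0.51 log units; beyond the scatter). Compound 2 stands at a limit of the assay: the limit of > 50000 nM in this assay, at which 1 of the 4 values shown sits.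

The compounds shown leave open whether an amine or a carboxylic acid on the fused ring, or a longer chain in place of methoxy, would move the number beyond the scatter. The unsubstituted phenyl stays the same in all four compounds, so a change there cannot be judged.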